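The compounds below may be only part of what the source reports. "The series", "measured", "known", "first", "only" and "open" are said of these compounds alone.

Going by the values given here, in a functional assay on NCI-H460 cells (Homo sapiens) for inhibition, read by sulforhodamine B assay, with a stated time of 48 h (a higher number here means a weaker inhibitor of growth, a lower number a stronger inhibitor of growth), compound 1 `CCOC(=O)c1nn(-c2ccccc2)c(-c2ccc(OC)cc2)c1CNC(C)(C)C` gives 119000 nM; 148000 nM (2 entries), the only true numbers in this small set. Compound 1 carries an ester where the two others carry a carboxylic acid. Compound 2 `Cc1ccc(-c2c(CNC(C)(C)C)c(C(=O)O)nn2-c2ccccc2)cc1` reaches only a limit of the assay, > 688000 nM. Compound 3 `COc1ccc(-c2c(CNC(C)(C)C)c(C(=O)O)nn2-c2ccccc2)cc1` also reaches only a limit, > 659000 nM. Compound 3 therefore has no exact number and stands on the weak side of the results for compound 1.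

Compound 4 `COc1ccc(-c2c(CNC(C)(C)C)c(C(=O)O)nn2-c2ccc(Cl)cc2)cc1` differs from compound 3 by one small change, chloro in place of hydrogen on an aromatic carbon, which turns phenyl to 4-chlorophenyl: chloro in place of hydrogen on an aromatic carbon. Among the compounds with values here, only one measured step involves a single change, methoxy in place of methyl on an aromatic carbon, and it is a step that the two limits leave unreadable from compound 2 to compound 3. It is a different change at a different place, and it offers no size to carry over. With nothing readable to build on, no step beyond the scatter is expected in this assay, and another limit would be no surprise. The expected step is an at least 1.3-fold lower number from compound 3 to compound 4 (0.11 log units; that floor lies within the scatter). Compound 4 is estimated at 500000 nM, with an expected range from 200000 nM to 800000 nM.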

Compound 4, concentration for 50% growth inhibition: > 605000 nM
Compound 4 gave a limit, no number (the forecaster's own chance of this, stated with the estimate: 70%); middle value at least 1.2-fold (0.08 log units) from the limit.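

Compound 4 gives only a limit of the assay, > 605000 nM. Compound 3 also gives only a limit, > 659000 nM, so no step can be read between compound 3 and compound 4. The compounds shown leave open how much, if at all, chloro in place of hydrogen on an aromatic carbon shifts growth inhibition in this assay.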